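From Hydroxy to a (2-Chlorophenyl)carbonyl Ester

This account rests on a few compounds, and the source may have more. Where it says the series, first, only, none or still open, it means among the compounds named here.

Compound 1 `C=C1C(=O)[C@@]23C(=O)OC[C@]4(C(=O)CCC(C)(C)[C@H]4C=O)[C@@H]2CC[C@@H]1[C@H]3O` carries a free hydroxy group on its core and, in a functional assay on CaEs17 cells (Homo sapiens) for cytotoxicity, read by MTT assay, with a stated time of 72 h (a lower number here means a stronger inhibitor, a higher number a weaker inhibitor), compound 1 gives 5850 nM. Among the three measured compounds this is the second highest number. Compound 2 `C=C1C(=O)[C@@]23C(=O)OC[C@]4(C(=O)CCC(C)(C)[C@H]4C=O)[C@@H]2CC[C@@H]1[C@H]3OC(=O)c1ccc(OC)cc1`, the (4-methoxyphenyl)carbonyl ester, gives 2980 nM in this assay, and compound 3 `C=C1C(=O)[C@@]23C(=O)OC[C@]4(C(=O)CCC(C)(C)[C@H]4C=O)[C@@H]2CC[C@@H]1[C@H]3OC(=O)c1ccccc1F`, the (2-fluorophenyl)carbonyl ester, gives 8550 nM. The step of a 2.0-fold lower number from compound 1 to compound 2 (0.29 log units; within the scatter) and the step of a 1.5-fold higher number from compound 1 to compound 3 (0.16 log units; within the scatter) both stay inside the scatter, so neither ester has clearly moved the number away from compound 1; only the comparison between the two esters, a 2.9-fold higher number from compound 2 to compound 3 (0.46 log units; beyond the scatter), reaches a modest size.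

Compound 4 `C=C1C(=O)[C@@]23C(=O)OC[C@]4(C(=O)CCC(C)(C)[C@H]4C=O)[C@@H]2CC[C@@H]1[C@H]3OC(=O)c1ccccc1Cl` differs from compound 1 by (2-chlorophenyl)carbonyl in place of hydrogen on an oxygen on a saturated carbon. Within the data shown here, the step that bears most directly on it is the one from compound 1 to compound 3, since that ester also carries a halogen on the phenyl ring, and it gave no change beyond the scatter. The step from compound 1 to compound 2 points the same way. Compound 4 is therefore expected to sit close to compound 1, with the expected step being a 1.2-fold higher number from compound 1 to compound 4 (0.08 log units; within the scatter). The estimate for compound 4 in this assay is 7000 nM, with a range from 3000 nM to 16000 nM.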

Compound 4, half-maximal inhibitory concentration: 2010 nM
Estimate against measurement, compound 4: 3.5-fold (0.54 log units) above; the measured number lies below the stated range.
By their numbers in this assay, from the lowest: compounds 4, 2, 1 and 3 (each within the scatter of the next, the first and the last beyond it).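

Among these compounds, with a 2.9-fold lower number from compound 1 to compound 4 (0.46 log units; beyond the scatter), the (2-chlorophenyl)carbonyl group gives the first step at this oxygen on a saturated carbon that lies beyond the scatter in this assay, so replacing the hydrogen of the hydroxy group can change the number, although compound 3, the (2-fluorophenyl)carbonyl ester, did not show this against compound 1. The halogen itself also counts here: chloro in place of fluoro on an aromatic carbon gives a 4.3-fold lower number from compound 3 to compound 4 (0.63 log units; beyond the scatter), the largest step among these compounds, so esters that differ only in this one atom are clearly separated. Compound 4 is not separated from the (4-methoxyphenyl)carbonyl ester, however, with a 1.5-fold lower number from compound 2 to compound 4 (0.17 log units; within the scatter), so two differently substituted phenyl rings can give numbers within the scatter of each other, while compound 3 stands apart from both.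

No measurement shown here explains why chloro and fluoro differ in this way. As far as these compounds go, it remains open whether a bromo group in place of the chloro would extend the step from fluoro to chloro, and whether an acetyl group on the same oxygen, with no phenyl ring, would move the number away from compound 1.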